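Extending the Acid Chain of Compound 2

The source may hold more compounds than are shown below. What is called first, only, known or untested is meant among the compounds shown, and "the series" means these compounds.

Compound 1 (`Nc1nc2[nH]c(CCCCCCC(=O)N[C@@H](CCC(=O)O)C(=O)O)cc2c(=O)[nH]1`) and compound 2 (`Nc1nc2[nH]c(CCCCCC(=O)O)cc2c(=O)[nH]1`) share one core. In a functional assay on PC43-10 cells (Cricetulus griseus) for inhibition, read by CellTiter-Blue, with a stated time of 96 h (a higher number here means a weaker inhibitor, a lower number a stronger inhibitor), compound 1 gives > 1000 nM as its reading, a limit and not a number. Compound 2 gives > 1000 nM in this assay as well, again a limit and not a number. Compound 2 therefore stands at the limit, with no exact value. Compared with compound 2, compound 3 (`Nc1nc2[nH]c(CCCCCCCCC(=O)O)cc2c(=O)[nH]1`) carries 3-carboxypropyl in place of carboxy on a saturated chain carbon, five bonds along the chain from an aromatic carbon. The expected step (a step that the limit leaves unreadable from compound 2 to compound 3) in this assay is none beyond the scatter, in either direction. Compound 3 is estimated at 1500 nM (800 nM to 5000 nM), and it may well give only a limit again.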

Compound 3, half-maximal inhibitory concentration: > 1000 nM
Compound 3 ended at the assay's limit; the forecaster's own chance of this, stated with the estimate: 85%; the middle value is on the limit's open side.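

Among the compounds shown here, no step from compound 2 to compound 3 can be read, since each reading is a limit and not a number: the limit of > 1000 nM in this assay, at which 3 of the 3 values shown sit. The compounds shown leave open how strongly any of them inhibits, and whether chain length matters.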